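Chloro for Methyl on the Shared Core of Compound 2

This account rests on a few compounds, and the source may have more. Where it says the series, first, only, none or still open, it means among the compounds named here.

Working notes on a small cytotoxicity series read in a functional assay on T-24 cells (Homo sapiens) for cytotoxicity, read by CCK-8 assay, with a stated time of 24 h; a lower number here means a stronger inhibitor, a higher number a weaker inhibitor. Compound 1 `C/C(=C\c1cc(-c2cccnc2)co1)C(N)=O` opens the set. In this assay compound 1 gives only the limit > 50000 nM. Compound 2 `C/C(=C\c1cc(-c2ccc(C)cc2)cs1)C(N)=O` carries a methyl on its outer ring. In this assay compound 2 likewise reaches only the limit > 50000 nM. Compound 3 `C/C(=C\c1cccc(-c2ccccc2)c1)C(N)=O` completes the measured set. In this assay compound 3 again gives the limit > 50000 nM. Going by the values given here, compound 2 therefore stands exactly where the rest of the series stands, at the limit of > 50000 nM in this assay, at which 3 of the 3 values shown sit, with no compound separating from the others and no step between measured compounds that differ in one place available.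

Compound 4 `C/C(=C\c1cc(-c2ccc(Cl)cc2)cs1)C(N)=O` differs from compound 2 by chloro in place of methyl on an aromatic carbon, para to a large group. Among the compounds with values here, no measured step informs this exchange. Given (the limit of > 50000 nM in this assay, at which 3 of the 3 values shown sit), no change beyond the scatter is expected in this assay, which means a step that the limit leaves unreadable from compound 2 to compound 4. Compound 4 is accordingly estimated at 60000 nM, with a range of 20000 nM to 200000 nM, and most likely reported again only as a limit.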

Compound 4, half-maximal inhibitory concentration: > 50000 nM
Compound 4 was reported as a limit (the forecaster's own chance of this, stated with the estimate: 75%); the middle value is on the limit's open side.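

In this assay compound 4 gives only a limit, > 50000 nM. Compound 2 is also held at a limit, so no step can be read between compound 2 and compound 4. The compounds shown leave open how chloro and methyl compare in this assay, and what on the shared core would give a value inside the assay's range.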